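Cytotoxicity notes on the pyrrolidinone urea series

A few compounds are considered here, and "the series" means these few. Any claim that something is new, unique, unknown or untested is made for them only; others in the source may bear on it.

Three compounds of the shared core have been run in a toxicity assay on HepG2 2.2.15 cells (Homo sapiens) for cytotoxicity, read by CellTiter-Glo; on this read-out lower numbers stand for higher toxicity in this test and higher numbers for lower toxicity in this test. Compound 1 `C[C@H]1Cn2ncc(N3CC(c4ccccc4)CC3=O)c2CN1S(=O)(=O)Nc1cc(F)c(F)c(F)c1` returns only a limit of the assay, > 2000 nM. Compound 2 `O=C1CC(C(F)(F)F)CN1c1cnn2c1CN(C(=O)Nc1cc(F)c(F)c(F)c1)C(C1CC1)C2` gives 115000 nM, the higher of the two plain numbers. Compound 3 `C[C@H]1Cn2ncc(N3CC(c4ccccc4)CC3=O)c2CN1C(=O)Nc1cc(F)c(F)c(F)c1` gives 12800 nM, lower than compound 2 by more than the usual scatter. Compound 1 and compound 3 share the phenyl-bearing core, so the limit of compound 1 cannot be set against them further.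

Compound 4 `O=C1CC(c2ncccn2)CN1c1cnn2c1CN(C(=O)Nc1cc(F)c(F)c(F)c1)C(C1CC1)C2` is not yet measured. It differs from compound 2 in one place: pyrimidin-2-yl in place of trifluoromethyl on a saturated ring carbon.

Nothing measured here tracks that change. The step of a 1.2-fold lower number from compound 2 to compound 4 (0.06 log units; within the scatter) is expected to stay within the scatter. For compound 4 the estimate in this assay is 100000 nM, between 35000 nM and 250000 nM.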

Compound 4, half-maximal cytotoxic concentration: > 200000 nM
Compound 4: a limit, no number; the forecaster's own chance of this, stated with the estimate: 25%; middle value at least 2.0-fold (0.30 log units) away from the limit.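

In this assay compound 4 returns a limit, not a number: the limit of > 200000 nM in this assay, at which 1 of the 4 values shown sits. Pyrimidin-2-yl in place of trifluoromethyl on this saturated ring carbon reads as an at least 1.7-fold higher number from compound 2 to compound 4 (0.24 log units; that floor lies within the scatter), so the true size of the step stays unknown and its floor does not separate the pair. What is new is that a six-membered aromatic ring with 2 hetero atoms is tolerated at this position without any drop in the number.

On these data alone, whether an amine or a carboxylic acid on this carbon would keep the reading this high remains open. Also open, as far as these compounds go, is how pyrimidin-2-yl would read on the core of compound 3.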